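The source may hold more compounds than are shown below. What is called first, only, known or untested is meant among the compounds shown, and "the series" means these compounds.

Within the data shown here, compound 1 `CC(=O)Nc1ccc(O)c(C(=O)/C=C/c2ccccc2)c1` stands highest of the two numbers so far in an ADME assay on MT4 cells (Homo sapiens) for cytotoxicity, read by MTT assay, with a stated time of 4 days (on this read-out lower numbers stand for higher toxicity in this test and higher numbers for lower toxicity in this test), where compound 1 gives 49400 nM; compound 2 `COc1ccccc1/C=C/C(=O)c1cc(NC(C)=O)ccc1O` gives 37800 nM, and the step of a 1.3-fold lower number from compound 1 to compound 2 (0.12 log units; within the scatter) lies within the scatter. Compound 3 `COc1ccc(/C=C/C(=O)c2cc(NC(C)=O)ccc2O)cc1` differs from compound 1 by methoxy in place of hydrogen on an aromatic carbon. Among the measured compounds shown here, the one measured step that bears on this, a 1.3-fold lower number from compound 1 to compound 2 (0.12 log units; within the scatter), also brings in methoxy in place of hydrogen on an aromatic carbon and stays within the scatter, so no step beyond the scatter is expected for compound 3 in this assay. Compound 3 is therefore estimated at 42000 nM, range 20000 nM to 90000 nM, an expected step of a 1.2-fold lower number from compound 1 to compound 3 (0.07 log units; within the scatter).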

Compound 3, half-maximal cytotoxic concentration: 38700 nM
For compound 3 the middle estimate is 1.1-fold (0.04 log units) above the measured one; low and high end bracket the measured number.
By their numbers in this assay, from the lowest: compounds 2, 3 and 1 (each within the scatter of the next).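

In this assay, methoxy on an aromatic carbon para to a large group gives a 1.3-fold lower number from compound 1 to compound 3 (0.11 log units; within the scatter), so this position, like the placement of methoxy in compound 2, shows no step beyond the scatter. Methoxy is therefore tolerated at two places on this ring without a readable change in cytotoxicity. No measured evidence bears on this result.

The compounds shown leave open whether an amine, a carboxylic acid or a longer chain such as butoxy at this position would move the number beyond the scatter. They also give no step beyond the scatter against which to judge this position.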